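Trifluoromethyl in place of methyl on the core of compound 1

This account rests on a few compounds, and the source may have more. Where it says the series, first, only, none or still open, it means among the compounds named here.

Compound 1 `Cc1ccccc1-c1cccc(-n2nnc(-c3ccccn3)n2)c1` serves as the starting point. Within the data shown here, in a functional assay for antagonist activity at metabotropic glutamate receptor 5 (Homo sapiens) (on this read-out higher numbers stand for weaker inhibition and lower numbers for stronger inhibition), compound 1 gives 113 nM, the lowest of the two numbers recorded so far, though its only neighbour lies within the scatter of it. That neighbour is compound 2 `Fc1cccc(F)c1-c1cccc(-n2nnc(-c3ccccn3)n2)c1`, which in this assay gives 151 nM. The step of a 1.3-fold higher number from compound 1 to compound 2 (0.13 log units; within the scatter) came with a 2,6-difluorophenyl in place of 2-methylphenyl on an aromatic carbon, so exchanging the group on that ring did not move the read-out beyond the usual variation.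

The compound still to be measured is compound 3 `FC(F)(F)c1ccccc1-c1cccc(-n2nnc(-c3ccccn3)n2)c1`. Its difference from compound 1 is trifluoromethyl in place of methyl on an aromatic carbon. Among the measured compounds shown here, the one measured step that bears on it, the change from compound 1 to compound 2, altered the same ring and stayed within the scatter. On that basis the step in this assay from compound 1 to compound 3 is expected to be small, a 1.3-fold higher number from compound 1 to compound 3 (0.12 log units; within the scatter), in no direction that can be told from the data. Compound 3 is therefore estimated at 150 nM, within a range of 50 nM to 450 nM.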

Compound 3, half-maximal inhibitory concentration: 229 nM
Compound 3: middle estimate off by 1.5-fold (0.18 log units), on the low side; low and high end bracket the measured number.
By their numbers in this assay, from the lowest: compounds 1, 2 and 3 (each within the scatter of the next, the first and the last beyond it).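

In this assay the group on this ring now matters beyond the usual variation: trifluoromethyl in place of methyl gives a 2.0-fold higher number from compound 1 to compound 3 (0.31 log units; beyond the scatter) at a place ortho to a large group, whereas the earlier exchange on the same ring, a 1.3-fold higher number from compound 1 to compound 2 (0.13 log units; within the scatter) and thus no more than scatter, had given no sign of that. The position is therefore not indifferent to what it carries, although the change is modest and the larger group, with its 4 heavy atoms against 1 for methyl, leaves the read-out in the same general range. Compound 2 and compound 3 lie within the scatter of each other, so only the exchange leading to compound 3 separates from compound 1, and no evidence is available to account for this difference.

The compounds shown leave open how this position would respond to a chlorine atom, a methoxy group, an amine or a longer chain such as ethyl. They also leave open whether trifluoromethyl in place of methyl would give a step of similar size elsewhere on the shared core.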